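The source may report more compounds than this note shows. Statements on the series, on what has been measured and on what is new or still open speak of the compounds shown alone.

Compound 3 `Brc1ccc(-c2cn3ccnc3c(-c3ccc4ncn(C5CCCCC5)c4c3)n2)cc1` stands second highest of the three measured in a functional assay on HL-60 cells (Homo sapiens) for inhibition, read by sulforhodamine B assay, with a stated time of 48 h, tested at 10 uM (on this read-out lower numbers stand for less inhibition and higher numbers for more inhibition at the one concentration tested (going by the name of the read-out)), giving 23.2%. Compound 2 `O=Cc1ccc(-c2cn3ccnc3c(-c3ccc4ncn(C5CCCCC5)c4c3)n2)cc1` gives 16.5% and compound 1 `COc1ccc(-c2cn3ccnc3c(-c3ccc4ncn(C5CCCCC5)c4c3)n2)cc1` gives 98.6%; the step of a number 6.7 percentage points higher from compound 2 to compound 3 (within the scatter) is within the scatter, while a number 75.4 percentage points lower from compound 1 to compound 3 (beyond the scatter) is beyond it. Compound 4 `COc1ccccc1-c1cn2ccnc2c(-c2ccc3ncn(C4CCCCC4)c3c2)n1` differs from compound 3 as follows: 2-methoxyphenyl in place of 4-bromophenyl on an aromatic carbon. Among the measured compounds shown here, the step of a number 75.4 percentage points lower from compound 1 to compound 3 (beyond the scatter) bears most on this change, since a methoxy group returns in compound 4, though it sits on the phenyl ring differently from compound 1, and no measured step covers that shift. Compound 4 is therefore expected to rise by a number 36.8 percentage points higher from compound 3 to compound 4 (beyond the scatter) in this assay, with an estimated value of 60%, ranging from 20% to 95%.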

Compound 4, a percentage reported as inhibition, at one concentration (the size of the read-out at that concentration, not a potency): 14.6%
Estimate against measurement, compound 4: 45.4 percentage points above; the measured number lies below the stated range.
By their numbers in this assay, from the lowest: compounds 4, 2 and 3 (each within the scatter of the next); then compound 1.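

In this assay, a methoxy group on the phenyl ring does not by itself carry the high reading: 2-methoxyphenyl in place of 4-methoxyphenyl gives a number 84 percentage points lower from compound 1 to compound 4 (beyond the scatter). The steps of a number 8.6 percentage points lower from compound 3 to compound 4 (within the scatter) and a number 1.9 percentage points lower from compound 2 to compound 4 (within the scatter) place 2-methoxyphenyl level with 4-bromophenyl and 4-formylphenyl, so among these compounds only 4-methoxyphenyl stands apart. No measurement shown here accounts for this difference. On these data alone, whether an amine, a carboxylic acid or a longer alkoxy chain in place of the methoxy of 4-methoxyphenyl would keep the reading of compound 1 remains open.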